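Compound 2 to compound 4: expected stability

The source may report more compounds than this note shows. Statements on the series, on what has been measured and on what is new or still open speak of the compounds shown alone.

In an ADME assay on microsomes from liver (Mus musculus) for metabolic stability, with a stated time of 10 min (on this read-out higher numbers stand for a more stable compound and lower numbers for a less stable compound), compound 2 (`NC(=O)[C@H]1CC[C@H](C(=O)N2CC[C@](c3ccc(C(F)(C(F)(F)F)C(F)(F)F)cc3)(S(=O)(=O)c3ccc(F)cc3)C2)CC1`) reads 100% and stands highest of the two compounds with a single number. For the measured compounds named here, compound 1 (`O=C([C@H]1CC[C@H](c2nnn[nH]2)CC1)N1CC[C@](c2ccc(C(F)(C(F)(F)F)C(F)(F)F)cc2)(S(=O)(=O)c2ccc(F)cc2)C1`) reads 73% and the one measured step is a number 27 percentage points higher from compound 1 to compound 2 (beyond the scatter) on exchanging 1H-tetrazol-5-yl for carbamoyl. Going by the values given here, compound 3 (`CS(=O)(=O)C1CCC(C(=O)N2CC[C@](c3ccc(C(F)(C(F)(F)F)C(F)(F)F)cc3)(S(=O)(=O)c3ccc(F)cc3)C2)CC1`), also without the carbamoyl group, reads 69%; "not determined" (no result reported) (2 entries) in its only entry with a number. Compound 4 (`CCC1(C(=O)N2CC[C@](c3ccc(C(F)(C(F)(F)F)C(F)(F)F)cc3)(S(=O)(=O)c3ccc(F)cc3)C2)CCS(=O)(=O)CC1`) differs thus: 4-ethyl-1,1-dioxothian-4-yl in place of 4-carbamoylcyclohexyl on a carbonyl carbon so the carbamoyl group is lost here too. With compound 1 at 73% and compound 3 at 69%; "not determined" (no result reported) (2 entries) as the guide, a modest fall is expected. The estimated change is a number 25 percentage points lower from compound 2 to compound 4 (beyond the scatter) in this read-out. For compound 4 the expected value is 75% (estimated range 55% to 95%).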

Compound 4, percent of the compound remaining: 0%
Estimate against measurement, compound 4: 75 percentage points above; measured number below the stated range.
By their numbers in this assay, from the lowest: compound 4; then compound 1; then compound 2.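

In this assay, for the compounds shown here, this place on the carbonyl carbon tolerates far less change than the earlier compounds suggested: a number 100 percentage points lower from compound 2 to compound 4 (beyond the scatter), and a number 73 percentage points lower from compound 1 to compound 4 (beyond the scatter). Losing the carbamoyl group alone does not bring a compound this low, as compound 1 holds 73%, so the 4-ethyl-1,1-dioxothian-4-yl group marks a separate, much larger step. Nothing measured here gives a cause for this fall.

As far as these compounds go, it remains open whether the ethyl group or the 1,1-dioxothian ring carries the fall. A methyl group or hydrogen in place of the ethyl could separate the two, and a carboxylic acid in place of the carbamoyl is also untested here.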